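A few compounds are considered here, and "the series" means these few. Any claim that something is new, unique, unknown or untested is made for them only; others in the source may bear on it.

Three compounds share one core and differ only in the aromatic ring attached to it. Compound 1 `CCCS(=O)(=O)Nc1ccc(F)c(C(=O)c2n[nH]c3ncc(-c4ccccc4F)cc23)c1F` carries a 2-fluorophenyl group, compound 2 `CCCS(=O)(=O)Nc1ccc(F)c(C(=O)c2n[nH]c3ncc(-c4cccc(C)c4)cc23)c1F` a 3-methylphenyl group, and compound 3 `CCCS(=O)(=O)Nc1ccc(F)c(C(=O)c2n[nH]c3ncc(-c4cccc(N)c4)cc23)c1F` a 3-aminophenyl group. In an assay for binding affinity to dual specificity mitogen-activated protein kinase kinase 4 (Homo sapiens), read by KINOMEscan, tested at 100 nM (on this read-out higher numbers stand for a weaker effect at the one concentration tested and lower numbers for a stronger effect), compound 1 gives 2%, compound 2 gives 15%, and compound 3 gives 1.6%. Compound 3 thus shows the lowest number of the three, yet its gap to compound 1 lies within the scatter, so the two cannot be told apart; only compound 2 stands clearly apart, as seen in a number 13.4 percentage points lower from compound 2 to compound 3 (beyond the scatter).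

Compound 4 `CCCS(=O)(=O)Nc1ccc(F)c(C(=O)c2n[nH]c3ncc(-c4ccc(C(F)(F)F)cc4)cc23)c1F` has not been measured. It differs from compound 3 as follows: 4-(trifluoromethyl)phenyl in place of 3-aminophenyl on an aromatic carbon. Among the measured compounds shown here, no measured step makes exactly this exchange. The nearest guides are a number 13.4 percentage points lower from compound 2 to compound 3 (beyond the scatter), where amino in place of methyl lowered the number modestly, and a number 13 percentage points higher from compound 1 to compound 2 (beyond the scatter), where 3-methylphenyl in place of 2-fluorophenyl raised it by a similar amount. Compound 4 resembles compound 2 in carrying a ring without the amino group, and compound 2 gave 15%. A modest rise is therefore expected, a number 10.4 percentage points higher from compound 3 to compound 4 (beyond the scatter). For compound 4 in this assay the expected value is 12%, with a range from 3% to 35%.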

Compound 4, a percentage reported as activity, at one concentration (the size of the read-out at that concentration, not a potency): 29%
Compound 4: middle estimate off by 17 percentage points, on the low side, within the range that was stated.
By their numbers in this assay, from the lowest: compounds 3 and 1 (each within the scatter of the next); then compound 2; then compound 4.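

Among the compounds shown here, the outer ring on the shared core now shows a wider spread in this assay than the earlier compounds revealed: a number 14 percentage points higher from compound 2 to compound 4 (beyond the scatter), a number 27.4 percentage points higher from compound 3 to compound 4 (beyond the scatter) and a number 27 percentage points higher from compound 1 to compound 4 (beyond the scatter), so 4-(trifluoromethyl)phenyl gives the weakest effect of the four at the one concentration tested. This exchange alters both the group and its place on the outer ring, as 3-methylphenyl gives way to 4-(trifluoromethyl)phenyl, so the rise cannot be assigned to either change alone. Nothing available explains why the number rises with this ring.

A 3-(trifluoromethyl)phenyl ring would help to separate the two changes, since it would keep the new group at the place held by the methyl of compound 2. Going by these compounds, it also remains open how a 4-aminophenyl ring, or a phenyl ring carrying a carboxylic acid or a longer chain such as butyl at that same place, would read in this assay, and so whether high numbers follow the trifluoromethyl group or extend to other groups there.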